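The source may report more compounds than this note shows. Statements on the series, on what has been measured and on what is new or still open speak of the compounds shown alone.

In a functional assay with Rattus norvegicus as the target (a lower number here means that less compound is needed, a higher number that more compound is needed for the effect), compound 1 `CC1(C)C=C(n2ccccc2=O)c2cc(S(=O)(=O)NCCO)ccc2O1` gives 110 nM, compound 3 `CC1(C)C=C(n2ccccc2=O)c2cc(S(=O)(=O)Nc3ccc(C#N)cc3)ccc2O1` gives 263 nM, and compound 2 `CC(C)NS(=O)(=O)c1ccc2c(c1)C(n1ccccc1=O)=CC(C)(C)O2` gives 676 nM, the highest of the three numbers. Compound 4 `CC1(C)C=C(n2ccccc2=O)c2cc(S(=O)(=O)N3CCOCC3)ccc2O1` remains unmeasured and differs from compound 2 in one place: morpholin-4-yl in place of isopropylamino on a sulfonyl sulfur. Among the compounds with values here, no measured step makes this exact change. The closest evidence comes from changes on the sulfonamide nitrogen: a 2.6-fold lower number from compound 2 to compound 3 (0.41 log units; beyond the scatter), and a 6.1-fold higher number from compound 1 to compound 2 (0.79 log units; beyond the scatter). Both other compounds lie below compound 2, so a modest downward step is expected, with wide uncertainty. The expected step is a 2.3-fold lower number from compound 2 to compound 4 (0.35 log units; beyond the scatter). Compound 4 is estimated at 300 nM, with an expected range from 100 nM to 900 nM.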

Compound 4, half-maximal effective concentration: 85.1 nM
Compound 4: middle estimate off by 3.5-fold (0.55 log units), on the high side; measured number outside the range, below it.
By their numbers in this assay, from the lowest: compounds 4 and 1 (each within the scatter of the next); then compound 3; then compound 2.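

Morpholin-4-yl carries no hydrogen-bond donor on the sulfonyl sulfur, yet the change gives a 7.9-fold lower number from compound 2 to compound 4 (0.90 log units; beyond the scatter) and a 3.1-fold lower number from compound 3 to compound 4 (0.49 log units; beyond the scatter), so a donor at this position is not needed for a low number among these compounds. The ring also matches the open (2-hydroxyethyl)amino chain, with a 1.3-fold lower number from compound 1 to compound 4 (0.11 log units; within the scatter) and so no real difference between the two. No measurement at hand explains these steps. The compounds shown leave open whether the ring oxygen matters, which a piperidin-1-yl group on the sulfonyl sulfur would address. As far as these compounds go, a piperazin-1-yl group, with its second ring nitrogen, remains equally open.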